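Swapping the Amine on the Sulfonyl Sulfur

The source may report more compounds than this note shows. Statements on the series, on what has been measured and on what is new or still open speak of the compounds shown alone.

Three compounds have been measured:
Compound 1 `O=C([C@@H]1CCCN(S(=O)(=O)c2ccc(S(=O)(=O)N3CC[C@@H](O)C3)cc2)C1)N1CCC(F)(F)CC1` gives 330 nM.
Compound 2 `CCN(CC)S(=O)(=O)c1ccc(S(=O)(=O)N2CCC[C@@H](C(=O)N3CCC(C(F)(F)F)CC3)C2)cc1` gives 370 nM.
Compound 3 `CCN(CC)S(=O)(=O)c1ccc(S(=O)(=O)N2CCC[C@@H](C(=O)N[C@H]3CC[C@@H](OC)CC3)C2)cc1` gives 2150 nM.

These numbers come from a functional assay on BXPC-3 cells (Homo sapiens) for inhibition, read by MTT assay, with a stated time of 7 days; on this read-out higher numbers stand for weaker inhibition and lower numbers for stronger inhibition. Compound 1 has the lowest number of the three, but its gap to compound 2 lies within the scatter, so those two cannot be ranked against each other; compound 3 sits clearly higher. Going by the values given here, the only step measured between compounds that differ in one place, a 5.8-fold higher number from compound 2 to compound 3 (0.76 log units; beyond the scatter), concerns the group on a carbonyl carbon, not the group on a sulfonyl sulfur.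

Compound 4 `CC(C)NS(=O)(=O)c1ccc(S(=O)(=O)N2CCC[C@@H](C(=O)N3CCC(F)(F)CC3)C2)cc1` differs from compound 1 at that other end of the shared core: isopropylamino in place of 3-hydroxypyrrolidin-1-yl on a sulfonyl sulfur. Among the compounds with values here, no measured step changes this position alone. Compounds 1 and 2 differ both at the sulfonyl sulfur and at the carbonyl carbon, and their values fall within the scatter of each other, which is the only hint that the amine on the sulfonyl sulfur can be varied without a large shift. On that thin basis compound 4 is expected to stay close to compound 1, with a 1.4-fold higher number from compound 1 to compound 4 (0.13 log units; within the scatter) not beyond the scatter, leaning slightly towards the weaker side. The estimate for compound 4 is 450 nM, within a range from 150 nM to 1400 nM.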

Compound 4, half-maximal inhibitory concentration: 470 nM
The estimate for compound 4 lay 1.0-fold (0.02 log units) below the measured number; the measured number falls inside the stated range.
By their numbers in this assay, from the lowest: compounds 1, 2 and 4 (each within the scatter of the next); then compound 3.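

Going by these compounds alone, this is the first measured step that changes only the group on the sulfonyl sulfur, since the earlier compounds offered no comparison with this position alone altered. In this assay, isopropylamino in place of 3-hydroxypyrrolidin-1-yl gives a 1.4-fold higher number from compound 1 to compound 4 (0.15 log units; within the scatter), so at this position a five-membered ring carrying a hydroxyl group and a defined stereocentre can be exchanged for an open, ringless group with fewer heavy atoms, with no shift that stands out from the usual variation between repeated measurements. Nothing among the available data explains this outcome, and the result records only the size of the step.

These two groups are only a small sample of what could sit on the sulfonyl sulfur, so the compounds shown do not tell how far this tolerance extends to a piperazin-1-yl ring, a longer chain such as octylamino, or a chain ending in a carboxylic acid. They also leave open whether the same exchange would give a similarly small step when the group on the carbonyl carbon is a different one, as a single pair cannot settle that.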